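The source may hold more compounds than are shown below. What is called first, only, known or untested is meant among the compounds shown, and "the series" means these compounds.

Measured so far:
Compound 1 `Cc1cccc(C#Cc2cc(C#N)cc([N+](=O)[O-])c2)n1` — 3.68 nM
Compound 2 `N#Cc1cc(C#Cc2ccccn2)cc([N+](=O)[O-])c1` — 1.32 nM

In a functional assay on HEK293 cells for antagonist activity at metabotropic glutamate receptor 5 (Rattus norvegicus), read by calcium flux (on this read-out lower numbers stand for stronger inhibition and higher numbers for weaker inhibition), compound 1 gives 3.68 nM while compound 2 gives 1.32 nM. Compound 2 holds the lowest of the two numbers; its nearest neighbour is compound 1, and the step of a 2.8-fold lower number from compound 1 to compound 2 (0.45 log units; beyond the scatter) comes from hydrogen in place of methyl on an aromatic carbon. Compound 3 `O=[N+]([O-])c1cc(F)cc(C#Cc2ccccn2)c1` is not yet measured. It differs from compound 2 by fluoro in place of cyano on an aromatic carbon. Among the measured compounds shown here, no measured step touches this position, so the expectation rests on the change alone. Compared with compound 2, a modest weakening is expected for compound 3, a 3.0-fold higher number from compound 2 to compound 3 (0.48 log units; beyond the scatter). Compound 3 is thus estimated at 4 nM, within 1 nM to 15 nM.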

Compound 3, half-maximal inhibitory concentration: 0.66 nM
Beside the measured number, compound 3's estimate is 6.1-fold (0.78 log units) above it, and the stated range ends above it.
By their numbers in this assay, from the lowest: compounds 3 and 2 (each within the scatter of the next); then compound 1.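

In this assay, fluoro in place of cyano gives a 2.0-fold lower number from compound 2 to compound 3 (0.30 log units; within the scatter). This position therefore tolerates the smaller fluoro group, and the cyano group is not required for a number this low. Nothing available explains why the two compounds read alike.

Still open, going by these compounds, is how other groups at this position, such as an amine, a methoxy group or a chlorine atom, would read. On these data alone, it is also open whether fluoro and cyano would still read alike with the methyl group of compound 1 present.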